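Replacing the oxolan-3-yl amide of compound 1 with propanoyl

The source may report more compounds than this note shows. Statements on the series, on what has been measured and on what is new or still open speak of the compounds shown alone.

Measured compounds:
compound 1 `CCn1c(-c2cnc(C)nc2)nc2c(N[C@H]3CCN(C(=O)C4CCOC4)C3)ncnc21`: 0.6
compound 2 `CCn1c(-c2ccc(C(F)(F)F)nc2)nc2c(O[C@H]3CCN(C(=O)c4cocn4)C3)ncnc21`: 2
compound 3 `CCn1c(-c2ccc(C(F)(F)F)nc2)nc2c(O[C@H]3CCN(C(=O)[C@H]4C[C@@H](OC)C4)C3)ncnc21`: 2.2

In a physicochemical assay for lipophilicity, read by HPLC (a higher number here means a more lipophilic compound, a lower number a more polar compound), compound 1 gives the lowest of the three numbers, with compound 2 and compound 3 both well beyond the scatter above it. Compound 4 `CCC(=O)N1CC[C@H](Nc2ncnc3c2nc(-c2cnc(C)nc2)n3CC)C1` differs from compound 1 in one place: ethyl in place of oxolan-3-yl on a carbonyl carbon. For the measured compounds named here, the only measured step at a carbonyl carbon, a number 0.20 log units higher from compound 2 to compound 3 (within the scatter), concerns a different pair of groups and lies within the scatter, so it offers little guidance. With one hetero atom and three carbons leaving, a modest rise in this assay is expected for compound 4, namely a number 0.40 log units higher from compound 1 to compound 4 (beyond the scatter). The estimated value of compound 4 is 1, between 0.5 and 1.5.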

Compound 4, distribution coefficient: 0.7
Compound 4: middle estimate off by 0.30 log units, on the high side; measured number inside the range.
By their numbers in this assay, from the lowest: compounds 1 and 4 (each within the scatter of the next); then compounds 2 and 3 (each within the scatter of the next).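

In this assay, ethyl in place of oxolan-3-yl on a carbonyl carbon gives a number 0.10 log units higher from compound 1 to compound 4 (within the scatter). For the compounds shown here, with the rest of compound 1 unchanged, removing the ring and its oxygen therefore leaves a difference that this assay does not resolve, something the earlier compounds could not show for this pair of groups. Nothing at hand accounts for this result.

On these data alone, whether an amine, a carboxylic acid or a longer chain on the same carbonyl carbon would also stay within the scatter remains open. So does whether this change would read the same in compound 2 or compound 3, which differ from compound 1 in more than one place.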